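This account rests on a few compounds, and the source may have more. Where it says the series, first, only, none or still open, it means among the compounds named here.

Compound 1, `CCN(CC)Cc1ccc2nc(NC(=O)N/N=C/c3c[nH]c4ccccc34)sc2c1`, gives 3300 nM in a functional assay on A549 cells (Homo sapiens) for cytotoxicity, read by MTT assay, with a stated time of 72 h; on this read-out lower numbers stand for stronger inhibition and higher numbers for weaker inhibition. Compound 2, `CCN(CC)Cc1ccc2nc(NC(=O)N/N=C/c3cn(Cc4cccc(Cl)c4)c4ccccc34)sc2c1`, carries a 3-chlorobenzyl in place of hydrogen on an aromatic nitrogen, and in this assay compound 2 gives 2410 nM. The step between them, a 1.4-fold lower number from compound 1 to compound 2 (0.14 log units; within the scatter), is small. Among the measured compounds shown here, compound 2 therefore shows the lower of the two numbers measured so far, but since its gap to compound 1 lies within the scatter, no order between the two can be read from it. Compound 3, `CN(C)Cc1ccc2nc(NC(=O)N/N=C/c3cn(Cc4cccc(Cl)c4)c4ccccc34)sc2c1`, differs from compound 2 by dimethylamino in place of diethylamino on a saturated chain carbon bound to an aromatic carbon. For the measured compounds named here, no measured step touches this part of the molecule; the only measured step, a 1.4-fold lower number from compound 1 to compound 2 (0.14 log units; within the scatter), concerns the aromatic nitrogen and itself stays within the scatter. The change at the saturated chain carbon is accordingly expected to give no step beyond the scatter, an expected 1.0-fold higher number from compound 2 to compound 3 (0.02 log units; within the scatter). Compound 3 is thus estimated at 2500 nM, within a range from 1000 nM to 6500 nM.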

Compound 3, half-maximal inhibitory concentration: 1240 nM
Estimate against measurement, compound 3: 2.0-fold (0.30 log units) above; measured number inside the range.
By their numbers in this assay, from the lowest: compounds 3, 2 and 1 (each within the scatter of the next, the first and the last beyond it).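

Among the compounds shown here, with dimethylamino in place of diethylamino on a saturated chain carbon bound to an aromatic carbon, this assay shows a 1.9-fold lower number from compound 2 to compound 3 (0.29 log units; within the scatter) and so gives the first reading at this position, which the earlier step did not touch. Across this one change, the two values cannot be told apart, so the shorter of these two amine substituents can stand here without a step beyond the scatter. Nothing available bears on what lies behind the size of this step.

On these data alone, it remains open whether a ring amine such as morpholine or pyrrolidine, or a primary amine, at this place would give a step beyond the scatter. As far as these compounds go, it is equally open whether a carboxylic acid there would do so, or whether the same amine change would give a similar step without the 3-chlorobenzyl on the aromatic nitrogen.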